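Moving the Hydroxyl Around the Phenyl Ring

The source may report more compounds than this note shows. Statements on the series, on what has been measured and on what is new or still open speak of the compounds shown alone.

Two compounds share one core: compound 1 `Oc1ccccc1-c1cc(-c2ccco2)cc(-c2ccccc2O)n1` and compound 2 `Oc1cccc(-c2cc(-c3ccco3)cc(-c3ccccc3O)n2)c1`. In an assay on isolated protein for inhibition of DNA topoisomerase 1 (Homo sapiens), with a stated time of 30 min, tested at 100 uM (a higher number here means a stronger effect of the compound at the concentration tested, a lower number a weaker effect), compound 1 gives 89.1%, and compound 2 gives 90.1%. Compound 2 stands highest of the two numbers, but its nearest neighbour is compound 1, and the two values lie within the scatter of each other, so no order between them can be read. Compound 3 `Oc1ccc(-c2cc(-c3ccco3)cc(-c3ccccc3O)n2)cc1` has not yet been measured in this assay; it differs from compound 2 in one place: 4-hydroxyphenyl in place of 3-hydroxyphenyl on an aromatic carbon. Among the compounds with values here, the only measured step that bears on this change is the earlier shift of the hydroxyl on the same phenyl ring, a number 1 percentage points higher from compound 1 to compound 2 (within the scatter), which stayed within the scatter. A second shift of the same kind is therefore expected to give no step beyond the scatter, a number 2.1 percentage points lower from compound 2 to compound 3 (within the scatter). Compound 3 is estimated at 88%, within a range from 74% to 97%.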

Compound 3, a percentage reported as inhibition, at one concentration (the size of the read-out at that concentration, not a potency): 83%
Estimate against measurement, compound 3: 5 percentage points above; the measured number falls inside the stated range.
By their numbers in this assay, from the lowest: compounds 3, 1 and 2 (each within the scatter of the next).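

Moving the hydroxyl once more, to give 4-hydroxyphenyl, yields a number 7.1 percentage points lower from compound 2 to compound 3 (within the scatter) in this assay, and the comparison with the first placement yields a number 6.1 percentage points lower from compound 1 to compound 3 (within the scatter) in the same assay. Within the data shown here, all three hydroxyphenyl placements on this aromatic carbon, next to the ring nitrogen, have now been read, and no step among them separates one placement from another, so the position of the hydroxyl on this ring shows no readable effect on this single-concentration read-out. Nothing available explains this result.

The compounds shown leave open whether an amine or a carboxylic acid in place of the hydroxyl on this ring would keep the read-out at this level, or whether the hydroxyl is needed here at all. They also leave open whether the three placements would stay together at a lower concentration.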